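A Longer Chain Before the Terminal Group

The source may hold more compounds than are shown below. What is called first, only, known or untested is meant among the compounds shown, and "the series" means these compounds.

Measured so far:
compound 1 `CN(C)C(=O)c1cc2cnc(Nc3ccc(C(=O)NCCCN=C=S)cc3F)nc2n1C1CCCC1`: 60.2%
compound 2 `CN(C)C(=O)c1cc2cnc(Nc3ccc(C(=O)NCCCCN=C=S)cc3F)nc2n1C1CCCC1`: 24.4%

In a functional assay on A549 cells (Homo sapiens) for inhibition, read by CCK-8 assay, with a stated time of 72 h, tested at 10 uM (on this read-out higher numbers stand for a stronger effect at the one concentration tested and lower numbers for a weaker effect), compound 1 gives 60.2%. Compound 2 gives 24.4%, the lower of the two numbers; the step of a number 35.8 percentage points lower from compound 1 to compound 2 (beyond the scatter) lies beyond the scatter. Compound 3 `CN(C)C(=O)c1cc2cnc(Nc3ccc(C(=O)NCCCCCCN=C=S)cc3F)nc2n1C1CCCC1` has not been measured. It differs from compound 2 by a group of 5 heavy atoms (3 carbon, 1 nitrogen, 1 sulfur; no ring) in place of a group of 3 heavy atoms (1 carbon, 1 nitrogen, 1 sulfur; no ring), on a saturated chain carbon, four bonds along the chain from an amide-type nitrogen.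

Among the compounds with values here, the one measured step that bears on this change is a number 35.8 percentage points lower from compound 1 to compound 2 (beyond the scatter), where a longer saturated chain to the same terminal group went with a large fall. Compound 3 lengthens that chain again, so a further fall is expected, limited by the floor of the read-out; the expected step is a number 12.4 percentage points lower from compound 2 to compound 3 (beyond the scatter). Compound 3 is therefore estimated at 12%, between 0% and 35%.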

Compound 3, a percentage reported as inhibition, at one concentration (the size of the read-out at that concentration, not a potency): 22.9%
Compound 3: middle estimate off by 10.9 percentage points, on the low side; low and high end bracket the measured number.
By their numbers in this assay, from the lowest: compounds 3 and 2 (each within the scatter of the next); then compound 1.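

In this assay, the longer chain of compound 3 cannot be told apart from the chain of compound 2: the step is a number 1.5 percentage points lower from compound 2 to compound 3 (within the scatter). Against the shortest chain the gap stays large, with a number 37.3 percentage points lower from compound 1 to compound 3 (beyond the scatter), so among these compounds only compound 1 stands apart. Nothing measured here explains why the read-out stays level across these two longer chains. Still open, from the compounds shown here alone, is how a chain shorter than that of compound 1 would read, and how an amine in place of the terminal group would compare.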